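Amino for methyl on the sulfonyl sulfur, cytotoxicity

This account rests on a few compounds, and the source may have more. Where it says the series, first, only, none or still open, it means among the compounds named here.

Measured compounds:
compound 1, `Cc1cc(C)cc(S(=O)(=O)n2c(SCC(=O)Nc3ccc(S(C)(=O)=O)cc3)nc3ccccc32)c1`: 10600 nM
compound 2, `Cc1cc(C)cc(S(=O)(=O)n2c(SCC(=O)Nc3ccc(S(N)(=O)=O)cc3)nc3ccccc32)c1`: 30900 nM
compound 3, `Cc1cc(C)cc(S(=O)(=O)n2c(OCC(=O)Nc3ccc(S(C)(=O)=O)cc3Cl)nc3ccccc32)c1`: > 228000 nM

In an ADME assay on MT4 cells (Homo sapiens) for cytotoxicity, read by MTT assay, with a stated time of 5 days (a lower number here means that less compound is tolerated, a higher number that more compound is tolerated), compound 1 gives 10600 nM. Compound 2 differs from it by amino in place of methyl on a sulfonyl sulfur, and the step of a 2.9-fold higher number from compound 1 to compound 2 (0.46 log units; beyond the scatter) is seen. Compound 3 reaches only the limit (the limit of > 228000 nM in this assay, at which 1 of the 3 values shown sits), so no number is known for it. The difference between the core of compound 1 and that of compound 3 is not broken down here. Compound 4, `Cc1cc(C)cc(S(=O)(=O)n2c(OCC(=O)Nc3ccc(S(N)(=O)=O)cc3Cl)nc3ccccc32)c1`, is not yet measured; it differs from compound 3 by amino in place of methyl on a sulfonyl sulfur, the same change as between compound 1 and compound 2. Because compound 1 to compound 2 gave a 2.9-fold higher number from compound 1 to compound 2 (0.46 log units; beyond the scatter), a step that the limit leaves unreadable from compound 3 to compound 4 is expected. Compound 4 is thus estimated at 400000 nM, between 200000 nM and 1000000 nM, most likely again only a limit.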

Compound 4, half-maximal cytotoxic concentration: > 227000 nM
Compound 4 gave a limit, no number; the forecaster's own chance of this, stated with the estimate: 85%; the middle value lies beyond the limit too.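

Compound 3 and compound 4 both reach only a limit in this assay, so no step can be read between them. The compounds shown leave open whether amino in place of methyl on a sulfonyl sulfur shifts the number at all on the core of compound 3.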